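The source may report more compounds than this note shows. Statements on the series, on what has been measured and on what is new or still open speak of the compounds shown alone.

Compound 3 `Cn1nc(-c2ccc(C(N)=O)cc2)s/c1=N\C1CCCCC1` stands at the top of the numbers measured in an in vivo ADME assay on the whole organism for pharmacokinetics, at a dose of 0.5 mg/kg by the intravenous route; on this read-out lower numbers stand for slow clearance and higher numbers for fast clearance: in this assay compound 3 gives 179 mL/min/kg, while its nearest neighbour, compound 2 `Cn1nc(-c2ccc(Cl)cc2)s/c1=N\c1ccc(F)c(C(=O)O)c1`, gives 3.9 mL/min/kg, a gap far beyond the scatter. Compound 1 `Cn1nc(-c2ccc(C(N)=O)cc2)s/c1=N\C1CCCC(O)C1` has been run more than once in this assay and does not enter the ordering with a single number; the record for it is the several entries of compound 1 in this assay, 34.4 mL/min/kg; 59.9 mL/min/kg (2 entries), that is, compound 1 gives 34.4 mL/min/kg; 59.9 mL/min/kg (2 entries), both entries well under compound 3 and well over compound 2.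

The piece follows the step from compound 3 to compound 4 `Cn1nc(-c2ccc(C(N)=O)cc2)s/c1=N\C1CCC(O)CC1`. The two structures differ in one place: hydroxy in place of hydrogen on a saturated ring carbon. Compound 1 likewise carries a hydroxy on a saturated ring carbon of a six-membered non-aromatic ring, at another position, and in this assay compound 1 gives 34.4 mL/min/kg; 59.9 mL/min/kg (2 entries).

On that ground a fall in clearance beyond the scatter is expected on going a 4.0-fold lower number from compound 3 to compound 4 (0.60 log units; beyond the scatter), landing near where compound 1 sits rather than near compound 2. Compound 4 is estimated to give 45 mL/min/kg in this assay, with a range from 20 mL/min/kg to 100 mL/min/kg.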

Compound 4, clearance: 66.9 mL/min/kg
Beside the measured number, compound 4's estimate is 1.5-fold (0.17 log units) below it; low and high end bracket the measured number.
By their numbers in this assay, from the lowest: compound 2; then compound 4; then compound 3.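

Hydroxy in place of hydrogen on a saturated ring carbon, three ring bonds from the ring atom that bears a large group, gives a 2.7-fold lower number from compound 3 to compound 4 (0.43 log units; beyond the scatter) in this assay. Within the data shown here, this is the first one-place comparison, and it shows that this ring position bears on clearance, since the change from cyclohexyl to 4-hydroxycyclohexyl moves the number beyond the scatter, though only modestly. Compound 4 gives 66.9 mL/min/kg, a number that does not stand apart from those of compound 1, which carries its hydroxy at another position of the ring, so the numbers shown do not tell these two ring positions apart: the several entries of compound 1 in this assay, 34.4 mL/min/kg; 59.9 mL/min/kg (2 entries)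

What the compounds shown leave open is whether an amine, a carboxylic acid or a methoxy group at this same ring carbon would take the number further down or back up. Also open, as far as these compounds go, is whether the step from hydrogen to hydroxy would carry over if the primary amide on the far side of the shared core were exchanged for a nitrile or a chlorine.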